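A Methoxy Group Added to Compound 1

The source may report more compounds than this note shows. Statements on the series, on what has been measured and on what is new or still open speak of the compounds shown alone.

Going by the values given here, in a functional assay on MDA-MB-231 cells (Homo sapiens) for antiproliferative activity, read by sulforhodamine B assay, with a stated time of 72 h (on this read-out lower numbers stand for stronger inhibition and higher numbers for weaker inhibition), compound 1 `O=C(/C=C/c1csc2ccccc12)c1ccccc1O` gives 5300 nM as one of only two measured numbers. The other comes from compound 2 `CCOc1ccc(O)c(C(=O)/C=C/c2csc3ccccc23)c1` with 6700 nM and the two lie within the scatter of each other. Compound 3 `COc1ccc(C(=O)/C=C/c2csc3ccccc23)c(O)c1` is still unmeasured and differs from compound 1 by methoxy in place of hydrogen on an aromatic carbon in one change: methoxy in place of hydrogen on an aromatic carbon, meta to a hydroxy group and para to a large group. Among the compounds with values here, one measured step bears on this, the similar swap of ethoxy in place of hydrogen on an aromatic carbon, which gave a 1.3-fold higher number from compound 1 to compound 2 (0.10 log units; within the scatter) and stands as the only guide. A single step is thin evidence, but no step beyond the scatter is expected in this assay here. The expected step is a 1.1-fold higher number from compound 1 to compound 3 (0.05 log units; within the scatter) for this small addition. Compound 3 is estimated at 6000 nM with an expected range from 2500 nM to 14000 nM in this measurement.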

Compound 3, half-maximal inhibitory concentration: 7400 nM
The estimate for compound 3 lay 1.2-fold (0.09 log units) below the measured number; low and high end bracket the measured number.
By their numbers in this assay, from the lowest: compounds 1, 2 and 3 (each within the scatter of the next).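

In this assay, methoxy on an aromatic carbon, meta to a hydroxy group and para to a large group, gives a 1.4-fold higher number from compound 1 to compound 3 (0.14 log units; within the scatter) and so leaves the number within the scatter. This place on the ring therefore carries a group of 2 heavy atoms without a change that can be told apart from repeat measurements, and the result joins a 1.3-fold higher number from compound 1 to compound 2 (0.10 log units; within the scatter) as a second small ether addition to this ring that stays within the scatter. No measurement here explains why the number holds at this place.

Going by these compounds, whether a hydroxy group, an amine, a carboxylic acid or a longer chain such as butoxy on this same carbon would move the number beyond the scatter stays open. Also open, on these data alone, is whether any change on this ring can take the number clearly away from that of compound 1.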